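The source may hold more compounds than are shown below. What is called first, only, known or untested is meant among the compounds shown, and "the series" means these compounds.

Measured so far in a functional assay on K562 cells (Homo sapiens) for inhibition, read by trypan blue exclusion, with a stated time of 72 h; on this read-out lower numbers stand for stronger inhibition and higher numbers for weaker inhibition:
- compound 1 `O=c1c(S(=O)(=O)c2ccc(F)cc2F)cc2cnc(Nc3ccc4[nH]ccc4c3)nc2n1C1CC1` — compound 1 gives 500 nM
- compound 2 `COC(=O)Cn1ccc2cc(Nc3ncc4cc(S(=O)(=O)c5ccc(F)cc5F)c(=O)n(C)c4n3)ccc21` — compound 2 gives 5000 nM

Going by the values given here, compound 1 holds the lower of the two numbers in this assay; compound 2 shows a number that stands well apart from it, beyond the scatter, but the two structures differ in more than one place and no single step between them is drawn.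

Compound 3 `O=c1c(S(=O)(=O)c2ccc(F)cc2F)cc2cnc(Nc3ccc4[nH]ccc4c3)nc2n1CC1CCCC1` is not yet measured in this assay. It differs from compound 1 in one place: cyclopentylmethyl in place of cyclopropyl on an aromatic nitrogen.

Among the compounds with values here, no measured step isolates this kind of change on the shared core, so there is nothing to anchor it. On the evidence available the expected step is a 1.4-fold higher number from compound 1 to compound 3 (0.15 log units; within the scatter), small and tending to a weaker number rather than a stronger one, and it may well fall within the scatter. The estimate for compound 3 in this assay is 700 nM, with a range from 250 nM to 2500 nM.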

Compound 3, half-maximal inhibitory concentration: 7000 nM
Beside the measured number, compound 3's estimate is 10-fold (1.00 log units) below it, outside the stated range (above it).
By their numbers in this assay, from the lowest: compound 1; then compounds 2 and 3 (each within the scatter of the next).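

In this assay, the substituent on the aromatic nitrogen of the shared core now has a measured step: cyclopentylmethyl in place of cyclopropyl gives a 14-fold higher number from compound 1 to compound 3 (1.15 log units; beyond the scatter), a large change beyond the scatter. With the rest of the structure unchanged, this position is shown to be sensitive to the exchange, and the higher number marks weaker inhibition on this read-out. Nothing measured on these compounds accounts for the size of the step.

The compounds shown leave open whether the step follows the larger ring or the methylene link, a question that cyclopentyl directly on the nitrogen would separate. Also open, from the compounds shown here alone, is how cyclobutyl, isopropyl, or a longer chain ending in an amine would compare with the cyclopropyl of compound 1 at this position.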